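The source may hold more compounds than are shown below. What is called first, only, known or untested is meant among the compounds shown, and "the series" means these compounds.

Notes on the series built on the shared core of compound 1 `O=C(/C=C/c1ccc2c(c1)B(O)OC2)c1ccc(I)cc1`. In an ADME assay on L929 cells (Mus musculus) for cytotoxicity, read by resazurin assay, with a stated time of 72 h (on this read-out lower numbers stand for stronger inhibition and higher numbers for weaker inhibition), compound 1 gives > 10 ug/mL, which is a limit of the assay and not a number. Compound 2 `O=C(/C=C/c1ccc2c(c1)B(O)OC2)c1cccc(F)c1` gives > 10 ug/mL in this assay, again a limit rather than a number. Compound 3 `O=C(/C=C/c1ccc2c(c1)B(O)OC2)c1ccco1` gives > 10 ug/mL in this assay, also only a limit. Consequently the step that the two limits leave unreadable from compound 1 to compound 2, the step that the two limits leave unreadable from compound 1 to compound 3 and the step that the two limits leave unreadable from compound 2 to compound 3 cannot be read in size; all three values sit at the limit of > 10 ug/mL in this assay, at which 3 of the 3 values shown sit.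

Compound 4 `O=C(/C=C/c1ccc2c(c1)B(O)OC2)c1ccc(-c2ccccc2)cc1` is not yet measured. It differs from compound 1 by phenyl in place of iodo on an aromatic carbon. Among the measured compounds shown here, no measured step alters a substituent on an aromatic carbon of the group on the carbonyl carbon; the three steps that exist each exchanged that whole group for 3-fluorophenyl or furan-2-yl, and none of them gave a readable size. For the measured compounds named here, the only pattern in the numbers so far is that every variation of the group on the carbonyl carbon has left the value at the limit, with no compound going against it. The expectation for compound 4 is therefore no step beyond the scatter, a step that the limit leaves unreadable from compound 1 to compound 4, in this assay. Compound 4 is expected to give 15 ug/mL in this assay, within 7 ug/mL to 40 ug/mL, most probably again reported only as a limit.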

Compound 4, half-maximal inhibitory concentration: > 10 ug/mL
Compound 4 was reported as a limit; the forecaster's own chance of this, stated with the estimate: 75%; the middle value does not contradict the limit.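

In this assay compound 4 gives > 10 ug/mL as a limit and not a number. The step between compound 1 and compound 4 thus cannot be read in size, and all values still sit together: the limit of > 10 ug/mL in this assay, at which 4 of the 4 values shown sit.

The compounds shown leave open whether any group on the carbonyl carbon or its aromatic ring brings the value to a readable number.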